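The compounds below may be only part of what the source reports. "The series", "measured", "known", "first", "only" and "open" are said of these compounds alone.

In this set compound 1, `COc1cc(-c2cc(/C=C/C(=O)c3ccc(N)cc3)[nH]n2)cc(OC)c1OC`, and compound 2, `COc1ccc(-c2cc(/C=C/C(=O)c3ccc(N)cc3)[nH]n2)cc1OC`, share one core, while compound 3, `COc1cc(C(=O)/C=C/c2cc(-c3cc(OC)c(OC)c(OC)c3)n[nH]2)cc(OC)c1OC`, carries the other; how the two cores differ is not broken down here. In a functional assay on CCRF-CEM cells (Homo sapiens) for cytotoxicity, read by sulforhodamine B assay, with a stated time of 48 h, tested at 100 uM (a lower number here means a stronger effect, a higher number a weaker effect of the compound at the concentration tested), compound 1 gives -21%, and compound 2 gives -22%. The change between them is hydrogen in place of methoxy on an aromatic carbon, and it makes a number 1 percentage points lower from compound 1 to compound 2 (within the scatter). In this assay compound 3 gives 2%, a number that stands beyond the scatter from compound 1 and from compound 2.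

Compound 4, `COc1ccc(-c2cc(/C=C/C(=O)c3cc(OC)c(OC)c(OC)c3)[nH]n2)cc1OC`, has not been measured. Among the measured compounds shown here, it differs from compound 3 by hydrogen in place of methoxy on an aromatic carbon, the same change as the one between compound 1 and compound 2, with the same surroundings at the place. Because the step of a number 1 percentage points lower from compound 1 to compound 2 (within the scatter) stayed within the scatter, compound 4 is expected to sit close to compound 3, so that the estimated step of a number 2 percentage points lower from compound 3 to compound 4 (within the scatter) is small in this assay. On this basis compound 4 is estimated at 0% in this assay, with an expected range from -15% to 15%.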

Compound 4, a percentage reported as activity, at one concentration (the size of the read-out at that concentration, not a potency): -13%
Beside the measured number, compound 4's estimate is 13 percentage points above it; measured number inside the range.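

On the core of compound 3, hydrogen in place of methoxy on an aromatic carbon makes a number 15 percentage points lower from compound 3 to compound 4 (beyond the scatter) in this assay. Set beside the same change on the core of compound 1, the two steps cannot be told apart, even though only the newer one lies beyond the scatter on its own: the same change on two cores in this assay, a number 1 percentage points lower (within the scatter) from compound 1 to compound 2 and a number 15 percentage points lower (beyond the scatter) from compound 3 to compound 4, 14 percentage points apart, within the scatter of two such steps The two pairs therefore fit a change that carries from one core to the other, but they do not show that its size is the same on both cores, nor that the cores respond differently, and two pairs support no general rule for the series.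

The compounds shown leave open whether a hydroxy group, a chlorine atom or a longer alkoxy chain on that aromatic carbon would move the read-out in the same direction. They also leave open how either core behaves when its other aromatic ring carries an amine in place of methoxy groups, or the reverse, since no pair shown isolates that difference.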